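Fluoro on the phenyl ring of compound 3

A few compounds are considered here, and "the series" means these few. Any claim that something is new, unique, unknown or untested is made for them only; others in the source may bear on it.

Measured in a toxicity assay on MT4 cells (Homo sapiens) for cytotoxicity, read by MTT assay; a lower number here means that less compound is tolerated, a higher number that more compound is tolerated:
Compound 1 `Cc1cc(-c2ccc(C#N)c(C#N)c2)ccc1Oc1cc(N)nc(Nc2ccc(C#N)cc2)n1` gives 76700 nM 
Compound 2 `Cc1cc(-c2cccc(F)c2)cc(C)c1Oc1cc(N)nc(Nc2ccc(C#N)cc2)n1` gives 24700 nM 
Compound 3 `Cc1cc(-c2ccccc2)ccc1Oc1cc(N)nc(Nc2ccc(C#N)cc2)n1` gives 20000 nM 

Compound 3 sits level with compound 2 within the usual scatter, and both numbers lie under that of compound 1. Compound 4 `Cc1cc(-c2cccc(F)c2)ccc1Oc1cc(N)nc(Nc2ccc(C#N)cc2)n1` differs from compound 3 by fluoro in place of hydrogen on an aromatic carbon, turning phenyl into 3-fluorophenyl. Among the compounds with values here, the only measured step (a 3.8-fold lower number from compound 1 to compound 3 (0.58 log units; beyond the scatter)) exchanged 3,4-dicyanophenyl for phenyl, a much larger change. Compound 2, which also carries 3-fluorophenyl but has an added methyl, gives 24700 nM and so stays level with compound 3. Only a small shift is therefore expected. The estimated step in this assay is a 1.1-fold higher number from compound 3 to compound 4 (0.04 log units; within the scatter) and is expected to stay within the scatter. Compound 4 is estimated at 22000 nM with an expected range of 12000 nM to 40000 nM.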

Compound 4, half-maximal cytotoxic concentration: 11300 nM
The estimate for compound 4 lay 1.9-fold (0.29 log units) above the measured number; the measured number lies below the stated range.
By their numbers in this assay, from the lowest: compounds 4, 3 and 2 (each within the scatter of the next, the first and the last beyond it); then compound 1.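

In this assay fluoro on the phenyl ring gives a 1.8-fold lower number from compound 3 to compound 4 (0.25 log units; within the scatter) and so does not clearly separate the two compounds. With 3-fluorophenyl held fixed, hydrogen in place of methyl on an aromatic carbon gives a 2.2-fold lower number from compound 2 to compound 4 (0.34 log units; beyond the scatter) and is the change here that passes the scatter by a small margin. Exchanging 3,4-dicyanophenyl for 3-fluorophenyl gives a 6.8-fold lower number from compound 1 to compound 4 (0.83 log units; beyond the scatter) as the largest of these steps.

No supporting measurement explains these steps. Going by these compounds, whether chloro, methoxy or an amine in place of fluoro would shift the number remains open.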